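The compounds below may be only part of what the source reports. "The series", "measured", "known", "first", "only" and "open" are said of these compounds alone.

Measured so far: compound 1 `CCOC(=O)N1CCC(CN2CC[C@H](NC(=O)c3cc(Cl)c(N)cc3OC)[C@H](OC)C2)CC1`, 377 nM; compound 2 `COc1cc(N)c(Cl)cc1C(=O)N[C@H]1CCN(CC2CCN(C(=S)C(C)C)CC2)C[C@H]1OC`, 155 nM; compound 3 `COc1cc(N)c(Cl)cc1C(=O)N[C@H]1CCN(CC2CCN(C(=O)CC(C)C)CC2)C[C@H]1OC`, 78 nM, all in an assay on COS-7 cells for displacement of a labelled ligand from 5-hydroxytryptamine receptor 4 (Homo sapiens), read by scintillation counting, with a stated time of 30 min; a higher number here means a weaker inhibitor, a lower number a stronger inhibitor.

Compound 3 gives the lowest number of the three: against compound 1 the step is a 4.8-fold lower number from compound 1 to compound 3 (0.68 log units; beyond the scatter), whereas against compound 2 the gap, a 2.0-fold lower number from compound 2 to compound 3 (0.30 log units; within the scatter), does not separate the two. Compound 4 `COc1cc(N)c(Cl)cc1C(=O)N[C@H]1CCN(CC2CCN(C(C)=O)CC2)C[C@H]1OC` differs from compound 3 by hydrogen in place of isopropyl on a saturated chain carbon bound to a carbonyl carbon. Among the measured compounds shown here, no measured step shortens this chain; the nearest guides are a 4.8-fold lower number from compound 1 to compound 3 (0.68 log units; beyond the scatter), where isobutyl in place of ethoxy on the carbonyl carbon lowered the number, and a 2.4-fold lower number from compound 1 to compound 2 (0.39 log units; beyond the scatter). For compound 4 the step is therefore expected to go upward, modestly, by about a 2.1-fold higher number from compound 3 to compound 4 (0.31 log units; beyond the scatter). For compound 4 the estimate in this assay is 160 nM, range 60 nM to 420 nM.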

Compound 4, half-maximal inhibitory concentration: 592 nM
For compound 4 the middle estimate is 3.7-fold (0.57 log units) below the measured one; the whole stated range lies below it.
By their numbers in this assay, from the lowest: compounds 3 and 2 (each within the scatter of the next); then compounds 1 and 4 (each within the scatter of the next).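

Replacing isopropyl with hydrogen on the saturated chain carbon bound to the carbonyl carbon gives a clear loss (a 7.6-fold higher number from compound 3 to compound 4 (0.88 log units; beyond the scatter)), so affinity at this position depends on the chain beyond the carbonyl, not on the carbonyl alone. Compound 4 also falls behind compound 2 (a 3.8-fold higher number from compound 2 to compound 4 (0.58 log units; beyond the scatter)), while methyl in place of ethoxy leaves no separation (a 1.6-fold higher number from compound 1 to compound 4 (0.20 log units; within the scatter)). No evidence available here accounts for these steps.

From the compounds shown here alone, whether a chain longer than isobutyl lowers the number further remains open. So does the effect of a cyclohexyl group or an amine on the carbonyl carbon.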